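Cytotoxicity on human cells: a dimethoxyphenyl variant

The compounds below may be only part of what the source reports. "The series", "measured", "known", "first", "only" and "open" are said of these compounds alone.

Compound 1 `Cc1nc(-c2ccccc2)sc1C(=O)CSc1nc(-c2cccc(Cl)c2)c(C#N)c(=O)[nH]1` has no result in an ADME assay on HEK293 cells (Homo sapiens) for cytotoxicity, read by MTT assay, with a stated time of 48 h; a higher number here means a weaker inhibitor, a lower number a stronger inhibitor: for compound 1 the entry reads "not determined" (no result reported). Going by the values given here, compound 2 `Cc1nc(-c2ccccc2)sc1C(=O)CSc1nc(-c2ccccc2)c(C#N)c(=O)[nH]1` is therefore the only compound of the series with a number: in this assay compound 2 gives 93500 nM, so it is a weak inhibitor of cell viability. Compound 3 `COc1ccc(-c2nc(SCC(=O)c3sc(-c4ccccc4)nc3C)[nH]c(=O)c2C#N)cc1OC` is not yet measured. It differs from compound 2 in one place (3,4-dimethoxyphenyl in place of phenyl on an aromatic carbon). Among the compounds with values here, no step between measured compounds is available, so a step of no more than the usual scatter is expected from compound 2 to compound 3 in this assay, estimated as a 1.2-fold lower number from compound 2 to compound 3 (0.07 log units; within the scatter). Compound 3 is thus expected to give about 80000 nM, within a range of 30000 nM to 200000 nM.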

Compound 3, half-maximal inhibitory concentration: 91800 nM
For compound 3 the middle estimate is 1.1-fold (0.06 log units) below the measured one; the range from low to high includes it.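

In this assay, going by these compounds alone, replacing phenyl with 3,4-dimethoxyphenyl on the aromatic carbon next to the ring nitrogen gives a 1.0-fold lower number from compound 2 to compound 3 (0.01 log units; within the scatter) and so adds a first reading at this position. The larger group, with its two hydrogen-bond acceptors, leaves compound 3 level with compound 2 on this read-out. Nothing at hand bears on why the two compounds read alike.

On these data alone, whether an amine or a carboxylic acid on this aromatic ring would read the same remains open. So does whether a single methoxy group would.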